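Swapping Trifluoromethyl for Chloro on the Urea Aryl Ring

The compounds below may be only part of what the source reports. "The series", "measured", "known", "first", "only" and "open" are said of these compounds alone.

Two measured compounds share one core and differ only on the aryl ring of the urea. Compound 1, `COc1cc2cc(Oc3ccc(NC(=O)Nc4cccc(C(F)(F)F)c4)cc3)c(C)nc2cc1OC`, gives 16600 nM in a functional assay on NCI-H322M cells (Homo sapiens) for inhibition, read by sulforhodamine B assay, with a stated time of 48 h; a lower number here means a stronger inhibitor of growth, a higher number a weaker inhibitor of growth. Compound 2, `COc1cc2cc(Oc3ccc(NC(=O)Nc4ccc(Cl)c(C(F)(F)F)c4)cc3)c(C)nc2cc1OC`, gives 6280 nM in this assay. Within the data shown here, the only step between them, a 2.6-fold lower number from compound 1 to compound 2 (0.42 log units; beyond the scatter), is modest but beyond the scatter. Compound 2 therefore stands at the lower of the two numbers, with compound 1 as its nearest neighbour.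

Compound 3, `COc1cc2cc(Oc3ccc(NC(=O)Nc4ccc(Cl)c(Cl)c4)cc3)c(C)nc2cc1OC`, has not yet been measured. It differs from compound 2 by chloro in place of trifluoromethyl on an aromatic carbon. Among the measured compounds shown here, no measured step alters this group; the one step on record, a 2.6-fold lower number from compound 1 to compound 2 (0.42 log units; beyond the scatter), concerns a different change on that ring and shows only that adding a chloro lowers the number modestly. It offers no direct guide to replacing a trifluoromethyl by a chloro. For the measured compounds named here, with no such precedent, the step of a 1.5-fold higher number from compound 2 to compound 3 (0.18 log units; within the scatter) is expected to be small, within or close to the scatter, with the number for compound 3 somewhat more likely to rise than to fall. Compound 3 is estimated at 9500 nM, with a range from 3500 nM to 26000 nM.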

Compound 3, concentration for total growth inhibition: 60300 nM
Beside the measured number, compound 3's estimate is 6.3-fold (0.80 log units) below it, outside the stated range (above it).
By their numbers in this assay, from the lowest: compound 2; then compound 1; then compound 3.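

In this assay, among these compounds, the trifluoromethyl group at this position turns out to matter far more than the one earlier step suggested: replacing its 4 heavy atoms with a single chloro, ortho to the existing chloro group, gives a 9.6-fold higher number from compound 2 to compound 3 (0.98 log units; beyond the scatter) and so undoes more than the earlier gain of a 2.6-fold lower number from compound 1 to compound 2 (0.42 log units; beyond the scatter) on adding a chloro to the ring. The added chloro also does not stand in for the trifluoromethyl group on this ring, since the change to 3,4-dichlorophenyl gives a 3.6-fold higher number from compound 1 to compound 3 (0.56 log units; beyond the scatter) and leaves compound 3 the highest of the three numbers. Nothing available explains the size of these steps.

What the compounds shown leave open is whether the high number for compound 3 reflects the loss of trifluoromethyl itself or something specific to chloro at this position, a question that a bromo, methyl or nitrile group there could begin to address. Also open, from the compounds shown here alone, is how a plain hydrogen at this position would read with the other chloro retained, and whether the same ordering would hold on a different aryl ring at the urea.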